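Replacing pyridin-2-yl in the series

This account rests on a few compounds, and the source may have more. Where it says the series, first, only, none or still open, it means among the compounds named here.

In a functional assay on DU-145 cells (Homo sapiens) for inhibition, read by trypan blue exclusion, with a stated time of 72 h (a higher number here means a weaker inhibitor, a lower number a stronger inhibitor), compound 1 `Cn1c(=O)c(S(=O)(=O)c2ccc(F)cc2F)cc2cnc(Nc3ccc4occc4c3)nc21` gives 15000 nM and compound 2 `Cn1c(=O)c(S(=O)(=O)c2ccc(F)cc2F)cc2cnc(Nc3ccccn3)nc21` gives 75000 nM as the higher of the two numbers, which makes compound 2 the weaker inhibitor of the pair. Compound 3 `Cn1c(=O)c(S(=O)(=O)c2ccc(F)cc2F)cc2cnc(NCc3ccc4[nH]ccc4c3)nc21` is still unmeasured. It differs from compound 2 by (1H-indol-5-yl)methyl in place of pyridin-2-yl on a nitrogen on an aromatic ring as the change, with (1H-indol-5-yl)methyl in place of pyridin-2-yl on a nitrogen on an aromatic ring.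

Among the measured compounds shown here, one measured step bears on this, the modest 5.0-fold higher number from compound 1 to compound 2 (0.70 log units; beyond the scatter) on that same nitrogen, which puts pyridin-2-yl in place of 1-benzofuran-5-yl. Like 1-benzofuran-5-yl, the entering group carries a five-membered aromatic ring and a six-membered aromatic ring, but it adds a methyl link that no measured compound tests. A step of similar size toward a lower number in this assay is therefore expected, resting on compound 1 at 15000 nM alone, and this single precedent leaves the range wide. The estimate is a 3.4-fold lower number from compound 2 to compound 3 (0.53 log units; beyond the scatter) as the expected step. Compound 3 is estimated at 22000 nM with a range from 6000 nM to 80000 nM expected.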

Compound 3, half-maximal inhibitory concentration: 100000 nM
For compound 3 the middle estimate is 4.5-fold (0.66 log units) below the measured one, and the stated range ends below it.
By their numbers in this assay, from the lowest: compound 1; then compounds 2 and 3 (each within the scatter of the next).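

In this assay, (1H-indol-5-yl)methyl on this nitrogen gives a 1.3-fold higher number from compound 2 to compound 3 (0.12 log units; within the scatter), so this change does not separate the entering group from pyridin-2-yl, even though it brings a five-membered aromatic ring and a six-membered aromatic ring, as 1-benzofuran-5-yl does. Set against 1-benzofuran-5-yl, the same group gives a 6.7-fold higher number from compound 1 to compound 3 (0.82 log units; beyond the scatter), which shows that carrying these two ring types does not by itself retain the lower number of compound 1 in this short series. No supporting data at hand account for either step.

The step from compound 1 to compound 3 combines the methyl link with the change of ring hetero atom, and the compounds shown do not separate the two; 1H-indol-5-yl directly on the nitrogen or (1-benzofuran-5-yl)methyl would do so. Also open, going by these compounds, is whether a different kind of substituent on this nitrogen, such as a longer chain ending in an amine or a carboxylic acid, would read lower than compound 1.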